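The source may hold more compounds than are shown below. What is called first, only, known or untested is meant among the compounds shown, and "the series" means these compounds.

Measured in a functional assay on MDA-MB-468 cells (Homo sapiens) for inhibition, read by sulforhodamine B assay, with a stated time of 48 h, tested at 10 uM; on this read-out lower numbers stand for a stronger effect and higher numbers for a weaker effect at the one concentration tested:
compound 1 `COc1cc(Cl)cc(-c2nn(-c3cccc(NC(=O)c4ccc(Cl)c(Cl)c4)c3)cc2-c2ccncc2)c1` gives 54.6%;
compound 2 `O=C(Nc1cccc(-n2cc(-c3ccncc3)c(-c3cc(O)cc(Cl)c3)n2)c1)Nc1ccc(Cl)c(Cl)c1` gives -1.88%;
compound 3 `COc1cc(Cl)cc(-c2nn(-c3cccc(NC(=O)Nc4ccc(Cl)c(C(F)(F)F)c4)c3)cc2-c2ccncc2)c1` gives -14.4%.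

Compound 3 stands lowest of the three. Its nearest neighbour is compound 2, higher by a margin beyond the scatter; the furthest is compound 1, the gap being the step of a number 69 percentage points lower from compound 1 to compound 3 (beyond the scatter). Compound 4 `COc1cc(Cl)cc(-c2nn(-c3cccc(NC(=O)Nc4ccc(Cl)c(Cl)c4)c3)cc2-c2ccncc2)c1` differs from compound 3 by chloro in place of trifluoromethyl on an aromatic carbon. Among the compounds with values here, no measured step covers this exchange; the only measured step concerns the amide-to-urea change and does not bear on it. Compound 2, which carries the same (3,4-dichlorophenyl)amino urea as compound 4, sits close to compound 3. The step of a number 8.4 percentage points higher from compound 3 to compound 4 (within the scatter) is therefore expected to stay within the scatter. Compound 4 is estimated at -6%, within -25% to 14%.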

Compound 4, a percentage reported as activity, at one concentration (the size of the read-out at that concentration, not a potency): 0.72%
The estimate for compound 4 lay 6.7 percentage points below the measured number; measured number inside the range.
By their numbers in this assay, from the lowest: compound 3; then compounds 2 and 4 (each within the scatter of the next); then compound 1.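

In this assay, chloro in place of trifluoromethyl gives a number 15.1 percentage points higher from compound 3 to compound 4 (beyond the scatter) and so shows that this aromatic carbon of the urea series responds to the exchange. Methyl in place of hydrogen on the oxygen gives a number 2.6 percentage points higher from compound 2 to compound 4 (within the scatter) and shows no readable effect of that exchange. (3,4-Dichlorophenyl)amino in place of 3,4-dichlorophenyl on the carbonyl carbon gives a number 53.9 percentage points lower from compound 1 to compound 4 (beyond the scatter) and shows that the large gain from the urea also holds without trifluoromethyl. No measured evidence gives a reason for these steps. Going by these compounds, how a nitrile, a methyl or a carboxylic acid on this aromatic carbon would read remains open.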